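A few compounds are considered here, and "the series" means these few. Any claim that something is new, unique, unknown or untested is made for them only; others in the source may bear on it.

Measured compounds:
- compound 1, `CCCS(=O)(=O)Nc1ccc(F)c(C(=O)c2n[nH]c3ncc(-c4cccc(C)c4)cc23)c1F`: 15%
- compound 2, `CCCS(=O)(=O)Nc1ccc(F)c(C(=O)c2n[nH]c3ncc(-c4ccccc4O)cc23)c1F`: 9%

Both compounds share one core and differ only in the aromatic group attached to it. In an assay for binding affinity to dual specificity mitogen-activated protein kinase kinase 4 (Homo sapiens), read by KINOMEscan, tested at 100 nM (a higher number here means a weaker effect of the compound at the concentration tested, a lower number a stronger effect), compound 1 gives 15%. In this assay compound 2 gives 9%. The only measured step between them, a number 6 percentage points lower from compound 1 to compound 2 (within the scatter), is too small to separate the two, so compound 2 stands level with compound 1 on the numbers shown.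

Compound 3, `CCCS(=O)(=O)Nc1ccc(F)c(C(=O)c2n[nH]c3ncc(-c4ccc(C)c(C)c4)cc23)c1F`, is not yet measured. It differs from compound 2 in one place: 3,4-dimethylphenyl in place of 2-hydroxyphenyl on an aromatic carbon. Among the measured compounds shown here, this is the same kind of exchange, at the same attachment point, as the one that led from compound 1 to compound 2. For the measured compounds named here, that single measured step, a number 6 percentage points lower from compound 1 to compound 2 (within the scatter), was within the scatter, and it is the only evidence that bears on the new change. On this basis no step beyond the scatter is expected from compound 2 to compound 3, that is, an expected step of a number 4 percentage points higher from compound 2 to compound 3 (within the scatter). Compound 3 is therefore estimated to give 13% in this assay, with a range from 4% to 30%.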

Compound 3, a percentage reported as activity, at one concentration (the size of the read-out at that concentration, not a potency): 20%
Estimate against measurement, compound 3: 7 percentage points below, and the stated range covers the measured number.
By their numbers in this assay, from the lowest: compounds 2, 1 and 3 (each within the scatter of the next, the first and the last beyond it).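

At this position, the aromatic group can shift the read-out by more than the scatter in this assay: 3,4-dimethylphenyl in place of 2-hydroxyphenyl gives a number 11 percentage points higher from compound 2 to compound 3 (beyond the scatter), a modest step. The group that leaves has 1 hydrogen-bond donor and 1 hydrogen-bond acceptor, the group that enters has neither, and the ring attached to the shared core stays a six-membered aromatic ring of carbon only, while adding a methyl to the 3-methylphenyl group gives only a number 5 percentage points higher from compound 1 to compound 3 (within the scatter), which cannot be told apart from no change. The compounds shown offer no evidence on what lies behind either step.

The step from 2-hydroxyphenyl to 3,4-dimethylphenyl removes a hydroxyl and brings in methyl groups in a single exchange, so these numbers cannot show whether the hydroxyl, the methyls or both account for it. As far as these compounds go, it also remains open whether a phenyl ring carrying an amine or a carboxylic acid at this same attachment point would read like 2-hydroxyphenyl, like the methyl-bearing groups, or differently from both.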